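The compounds below may be only part of what the source reports. "The series", "measured", "known", "first", "only" and "open" are said of these compounds alone.

Compound 2 `O=C(CC(SC(=S)N1CCOCC1)c1ccccc1)c1ccccc1` gives 1650 nM in a functional assay on the whole organism for inhibition, with Cicer arietinum as the target, with a stated time of 7 days; a lower number here means a stronger inhibitor, a higher number a weaker inhibitor; it stands alongside compound 1 `O=C(CC(SC(=S)N1CCCCC1)c1ccccc1)c1ccccc1`, which gives 1850 nM, and the two sit within the scatter of each other, as a 1.1-fold lower number from compound 1 to compound 2 (0.05 log units; within the scatter) shows. Compound 3 `CN(C)C(=S)SC(CC(=O)c1ccccc1)c1ccccc1` differs from compound 2 by dimethylamino in place of morpholin-4-yl on a thiocarbonyl carbon. Going by the values given here, only the step from compound 1 to compound 2 bears on this change, since it also swapped the group on the thiocarbonyl carbon, and that step stayed within the scatter, so no shift beyond the scatter is expected in this assay. Compound 3 is therefore estimated at 1700 nM, within a range of 900 nM to 3300 nM. The expected step is a 1.0-fold higher number from compound 2 to compound 3 (0.01 log units; within the scatter).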

Compound 3, half-maximal inhibitory concentration: 2430 nM
Compound 3: middle estimate off by 1.4-fold (0.16 log units), on the low side; low and high end bracket the measured number.
By their numbers in this assay, from the lowest: compounds 2, 1 and 3 (each within the scatter of the next).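

In this assay, replacing either ring with the open dimethylamino group leaves the numbers within the scatter: the data show a 1.5-fold higher number from compound 2 to compound 3 (0.17 log units; within the scatter) and a 1.3-fold higher number from compound 1 to compound 3 (0.12 log units; within the scatter). The earlier pair compared only morpholin-4-yl with piperidin-1-yl, whereas these steps show that, among these three compounds, a ring on the thiocarbonyl carbon makes no difference beyond the scatter. No supporting measurement is available to explain this result. Still open, on these data alone, is whether a longer-chain group such as diethylamino, or a piperazin-1-yl ring with its second amine, would move the number beyond the scatter.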